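Swapping a pyridine for a dichlorophenyl on the amide nitrogen

The source may hold more compounds than are shown below. What is called first, only, known or untested is meant among the compounds shown, and "the series" means these compounds.

Of the compounds shown here, two from this series have numbers so far. Compound 1 `COc1ccc(N2NC3=CC[C@@H](OC)O[C@@]3(c3ccccc3)CCC2=O)cc1` gives 3100 nM in a functional assay on HCT-116 cells (Homo sapiens) for cytotoxicity, read by sulforhodamine B assay, with a stated time of 48 h; a higher number here means a weaker inhibitor, a lower number a stronger inhibitor. Compound 2 `CO[C@@H]1CC=C2N(c3ccccn3)C(=O)C[C@]2(c2ccccc2)O1` gives 7300 nM in this assay, the higher of the two numbers, with compound 1 lying below it by a gap beyond the usual scatter. Among the measured compounds shown here, the two share the phenyl-bearing fused core but differ in more than one place, so the data give no single step between them.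

Compound 3 `CO[C@@H]1CC=C2N(c3cc(Cl)cc(Cl)c3)C(=O)C[C@]2(c2ccccc2)O1` is the next compound and has not yet been measured. It differs from compound 2 in one place: 3,5-dichlorophenyl in place of pyridin-2-yl on an amide-type nitrogen in a ring. For the measured compounds named here, no measured step of this kind exists among the compounds with numbers, so the size of the change in this assay can only be guessed. A modest move is expected, more likely toward a lower number than a higher one, and possibly staying within the scatter. For compound 3 the estimate in this assay is 4000 nM, with a range from 1200 nM to 13000 nM, which corresponds to an expected step of a 1.8-fold lower number from compound 2 to compound 3 (0.26 log units; within the scatter).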

Compound 3, half-maximal inhibitory concentration: 11200 nM
The estimate for compound 3 lay 2.8-fold (0.45 log units) below the measured number; the measured number falls inside the stated range.
By their numbers in this assay, from the lowest: compound 1; then compounds 2 and 3 (each within the scatter of the next).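

Among the compounds shown here, the first step that changes a single place, a 1.5-fold higher number from compound 2 to compound 3 (0.19 log units; within the scatter) in this assay, lies within the usual scatter. At this position on the amide-type nitrogen, pyridin-2-yl and 3,5-dichlorophenyl therefore cannot be told apart by this read-out, even though the swap replaces a ring with one hetero atom and one hydrogen-bond acceptor by a carbon-only ring with two chlorines and no acceptor. No supporting measurement bears on why the two compounds read alike, and the result stands as an observation only.

The compounds shown leave open whether any group at this position can produce a step beyond the scatter, for example an amine or a carboxylic acid on the aromatic ring, or a simple alkyl chain such as ethyl on the nitrogen in place of the ring. They also leave open whether the two chlorines matter individually, since a single chlorine or a methoxy group on the phenyl ring would be needed to separate their contributions from that of the ring itself.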